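Spirocyclic Diamine Replaces Hydroxymethylpiperidine on the Shared Core

A few compounds are considered here, and "the series" means these few. Any claim that something is new, unique, unknown or untested is made for them only; others in the source may bear on it.

Of the compounds shown here, three of a common core have been measured in a physicochemical assay for solubility, measured as kinetic solubility; a lower number here means a less soluble compound, a higher number a more soluble compound. Compound 1 `O=C(Nc1ccnnc1)c1cc(N2CCNCC2)ccc1OCc1ccccc1` gives 98000 nM. Compound 2 `O=C(Nc1ccnnc1)c1cc(N2CCC(F)CC2)ccc1OCc1ccccc1` gives 20000 nM, and compound 3 `O=C(Nc1ccnnc1)c1cc(N2CCC(CO)CC2)ccc1OCc1ccccc1` gives 323000 nM. Compound 3 stands highest of the three: the nearest is compound 1, and the step is a 3.3-fold higher number from compound 1 to compound 3 (0.52 log units; beyond the scatter); the furthest is compound 2, with a 16-fold higher number from compound 2 to compound 3 (1.21 log units; beyond the scatter). Between the two lower compounds the step is a 4.9-fold lower number from compound 1 to compound 2 (0.69 log units; beyond the scatter).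

Compound 4 `CN1CC2(CCN(c3ccc(OCc4ccccc4)c(C(=O)Nc4ccnnc4)c3)CC2)C1` has not yet been measured. It differs from compound 3 in one place: a group of 10 heavy atoms (8 carbon, 2 nitrogen; one four-membered non-aromatic ring with 1 hetero atom, one six-membered non-aromatic ring with 1 hetero atom) in place of a group of 8 heavy atoms (6 carbon, 1 nitrogen, 1 oxygen; one six-membered non-aromatic ring with 1 hetero atom), on an aromatic carbon. Going by the values given here, two measured steps bear on this change. The step from compound 2 to compound 3 shows that a hydroxymethyl on the saturated ring carried a large rise, and the step from compound 1 to compound 3 shows that exchanging the piperazin-1-yl for the hydroxymethyl-bearing ring carried a modest rise. Compound 4 keeps a second ring nitrogen but loses the hydroxymethyl, so a modest fall from compound 3 is expected, of roughly a 3.2-fold lower number from compound 3 to compound 4 (0.51 log units; beyond the scatter). For compound 4 the estimate in this assay is 100000 nM, within 30000 nM to 300000 nM.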

Compound 4, solubility: 266000 nM
For compound 4 the middle estimate is 2.7-fold (0.42 log units) below the measured one; the range from low to high includes it.
By their numbers in this assay, from the lowest: compound 2; then compound 1; then compounds 4 and 3 (each within the scatter of the next).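

At the place meta to the (pyridazin-4-yl)carbamoyl group, this assay does not separate the two groups, with a 1.2-fold lower number from compound 3 to compound 4 (0.08 log units; within the scatter), so the hydroxymethyl is not needed for a number at this level, and a group with 0 hydrogen-bond donors sits level with it. The new group also keeps the lead over the two other six-membered rings, with a 13-fold higher number from compound 2 to compound 4 (1.12 log units; beyond the scatter) and a 2.7-fold higher number from compound 1 to compound 4 (0.43 log units; beyond the scatter), which shows that more than one kind of group at this place can stand clear of the 4-fluoropiperidin-1-yl and piperazin-1-yl compounds. No measurement offered here accounts for these numbers.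

What the compounds shown leave open is whether a longer chain such as hydroxyethyl or a carboxylic acid on the six-membered ring would give a similar number. On these data alone, it is equally open what replacing the methyl on the four-membered ring's nitrogen with an acetyl group would do.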